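The compounds below may be only part of what the source reports. "The series", "measured", "known", "first", "only" and "open" are said of these compounds alone.

In an ADME assay on MRC5 cells (Homo sapiens) for cytotoxicity, read by fluorescence and resazurin assay, with a stated time of 3 days (on this read-out higher numbers stand for lower toxicity in this test and lower numbers for higher toxicity in this test), three compounds have been read so far, and none of them gives a number. Compound 1 `O=C(Nc1cc(-c2ccccn2)n[nH]1)N1CCC(c2ccc(F)cc2)CC1` gives > 64000 nM, which is a limit of the assay. Compound 2 `O=C(Nc1cc(-c2ccccn2)n[nH]1)N1CCC(Oc2ccccc2)CC1` gives > 64000 nM, which is also a limit. Compound 3 `O=C(NCc1cccc(Cl)c1)Nc1cc(-c2ccccn2)n[nH]1` gives > 64000 nM, again a limit. Compound 2 therefore stands only at a limit, and the two other values beside it are limits too. What the series offers so far is the limit of > 64000 nM in this assay, at which 3 of the 3 values shown sit.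

Compound 4 `O=C(Nc1cc(-c2ccccn2)n[nH]1)N1CCC(Oc2ccccn2)CC1` has not yet been measured. It carries pyridin-2-yl in place of phenyl on an oxygen on a saturated carbon, and the counted difference reads (pyridin-2-yl in place of phenyl on an oxygen on a saturated carbon).

For the measured compounds named here, only one measured step changes a single place, and that is a step that the two limits leave unreadable from compound 1 to compound 2. Going by the values given here, it gives no size to carry over, and no measured step touches this exchange directly. With only the shared limit of the three measured compounds to go on, no step beyond the scatter is expected in this assay, in either direction. The expected size is a number no higher from compound 2 to compound 4 (the limit leaves the size open). For compound 4 the estimate is 64000 nM, with an expected range from 32000 nM to 64000 nM.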

Compound 4, half-maximal cytotoxic concentration: > 63000 nM
Compound 4 was reported as a limit; the forecaster's own chance of this, stated with the estimate: 85%; the middle value lies beyond the limit too.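

In this assay compound 4 gives > 63000 nM, which is a limit. The steps from compound 2 to compound 4 and from compound 1 to compound 4 cannot be read. The compounds shown leave open whether any of these exchanges changes the half-maximal cytotoxic concentration, and at what concentration any of these compounds would reach it.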